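From Isobutyl to Sec-Butyl: One Small Swap

A few compounds are considered here, and "the series" means these few. Any claim that something is new, unique, unknown or untested is made for them only; others in the source may bear on it.

Measured in a functional assay for inhibition, with Rattus norvegicus as the target; on this read-out lower numbers stand for stronger inhibition and higher numbers for weaker inhibition:
compound 1 `CC(C)C/N=c1\c(O)c(O)\c1=N/Cc1ccc(C#N)cc1` gives 10200 nM
compound 2 `Cc1cc(Cl)cc(Cl)c1C/N=c1\c(O)c(O)\c1=N/C(C)(C)C` gives 220 nM
compound 3 `CC(C)(C)/N=c1\c(O)c(O)\c1=N/Cc1ccc(C#N)c(Cl)c1` gives 1100 nM

Of these three, compound 1 has the highest number and so shows the weakest inhibition. The other two compounds both lie lower, by more than the usual scatter between repeated measurements. Compound 4 `CC[C@@H](C)/N=c1\c(O)c(O)\c1=N/Cc1ccc(C#N)cc1` has not been measured yet. Going by the values given here, it keeps the rest of compound 1 and puts sec-butyl in place of isobutyl on a double-bonded nitrogen as its only change. Among the compounds with values here, no two measured compounds differ in one place only, so this swap has no direct precedent. The nearest hints are compound 3 at 1100 nM and compound 2 at 220 nM with tert-butyl on that nitrogen, but both also differ from compound 1 elsewhere, which makes the hint weak. A moderate step to a lower number is therefore expected, and a 2.9-fold lower number from compound 1 to compound 4 (0.46 log units; beyond the scatter) is its estimated size. For compound 4 the estimated value is 3500 nM (expected range 1000 nM to 10000 nM).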

Compound 4, half-maximal inhibitory concentration: 4000 nM
Compound 4: middle estimate off by 1.1-fold (0.06 log units), on the low side; the measured number falls inside the stated range.
By their numbers in this assay, from the lowest: compound 2; then compound 3; then compound 4; then compound 1.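

Changing isobutyl to sec-butyl on a double-bonded nitrogen gives, in this assay, a 2.6-fold lower number from compound 1 to compound 4 (0.41 log units; beyond the scatter), a modest step but one beyond the usual scatter. The two compounds contain the same atoms, joined differently, so this position responds to a rearrangement of the four carbons alone, with none added or removed, in a change that also introduces a defined stereocentre. Nothing available here explains the shift in terms of a measured property.

As far as these compounds go, how a straight n-butyl chain, a cyclobutyl ring or the mirror-image form of sec-butyl would compare with compound 4 at this nitrogen remains open. Also open, from the compounds shown here alone, is whether the same swap would give a similar step with a different group on the rest of the molecule.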